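The source may report more compounds than this note shows. Statements on the series, on what has been measured and on what is new or still open speak of the compounds shown alone.

In a functional assay on MCF7 cells (Homo sapiens) for inhibition, read by MTT assay, with a stated time of 72 h (a higher number here means a weaker inhibitor, a lower number a stronger inhibitor), compound 1 `Nc1ncnc2c1c(-c1cnc3[nH]ccc3c1)nn2CCCCCCCCC(=O)NO` gives 24700 nM and compound 3 `Nc1nc2cc(-c3nn(CCCCC(=O)NO)c4ncnc(N)c34)ccc2o1` gives 14000 nM, two values within the scatter of each other. Compound 2 `Nc1nc2cc(-c3nn(CCCCCCCCCC(=O)NO)c4ncnc(N)c34)ccc2o1` gives > 50000 nM, which is a limit of the assay. Compound 4 `Nc1ncnc2c1c(-c1cnc3[nH]ccc3c1)nn2CCC(=O)NO` differs from compound 1 by hydroxycarbamoyl in place of 6-(hydroxycarbamoyl)hexyl on a saturated chain carbon, two bonds along the chain from an aromatic nitrogen, with hydroxycarbamoyl in place of 6-(hydroxycarbamoyl)hexyl on a saturated chain carbon, two bonds along the chain from an aromatic nitrogen. For the measured compounds named here, the one measured step of this kind is an at least 3.5-fold lower number from compound 2 to compound 3 (0.55 log units; beyond the scatter), which is beyond the scatter but lies on a core different from that of compound 1. A modest move to a lower number in this assay is therefore expected, and the expected step is a 2.5-fold lower number from compound 1 to compound 4 (0.39 log units; beyond the scatter). For compound 4 the estimate is 10000 nM, with an expected range from 3000 nM to 40000 nM.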

Compound 4, half-maximal inhibitory concentration: > 150000 nM
Compound 4 was reported as a limit; the forecaster's own chance of this, stated with the estimate: 20%; middle value at least 15-fold (1.17 log units) from the limit.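

In this assay, shortening the chain on the core of compound 1 raises the number, an at least 6.0-fold higher number from compound 1 to compound 4 (0.78 log units; beyond the scatter), whereas on the other core the number falls, an at least 3.5-fold lower number from compound 2 to compound 3 (0.55 log units; beyond the scatter), and compound 3 keeps a longer chain than compound 4. Shortening the chain therefore does not move the number in one direction across the compounds shown. The true size of the new step stays unknown because compound 4 stands at a limit: the limit of > 150000 nM in this assay, at which 1 of the 4 values shown sits.

The compounds shown do not separate the effect of the core from that of the chain length remaining. Going by these compounds, a chain of intermediate length on the core of compound 1, or a carboxylic acid in place of the hydroxycarbamoyl end, remains open.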